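Aryl swap on the tetrazole: pyridinyl to thienyl

A few compounds are considered here, and "the series" means these few. Any claim that something is new, unique, unknown or untested is made for them only; others in the source may bear on it.

Compound 1 `CCCCCCCCc1ccc(OCC(=O)Cn2nnnc2C)cc1` gives 41 nM in an assay on microsomes from brain for inhibition of Fatty-acid amide hydrolase 1 (Rattus norvegicus), read by fluorescence and HPLC, with a stated time of 60 min; on this read-out higher numbers stand for weaker inhibition and lower numbers for stronger inhibition. Compound 2 `CCCCCCCCc1ccc(OCC(=O)Cn2nnnc2-c2cccnc2)cc1` gives 190 nM in this assay, the higher of the two numbers. Among the compounds with values here, the one measured step, a 4.6-fold higher number from compound 1 to compound 2 (0.67 log units; beyond the scatter), is the only comparison bearing on compound 3 `CCCCCCCCc1ccc(OCC(=O)Cn2nnnc2-c2cccs2)cc1`, and it concerns a different swap. The change from compound 2 to compound 3 is thiophen-2-yl in place of pyridin-3-yl on an aromatic carbon. With a single indirectly related step, the expected step of a 1.6-fold lower number from compound 2 to compound 3 (0.20 log units; within the scatter) is small and of uncertain direction. Compound 3 is estimated at 120 nM in this assay, within 40 nM to 350 nM.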

Compound 3, half-maximal inhibitory concentration: 55 nM
The estimate for compound 3 lay 2.2-fold (0.34 log units) above the measured number, and the stated range covers the measured number.
By their numbers in this assay, from the lowest: compounds 1 and 3 (each within the scatter of the next); then compound 2.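

Thiophen-2-yl in place of pyridin-3-yl gives a 3.5-fold lower number from compound 2 to compound 3 (0.54 log units; beyond the scatter) in this assay, so the loss seen with pyridin-3-yl does not extend to every aromatic ring on this carbon of the five-membered aromatic ring with 4 nitrogen. Against methyl, thiophen-2-yl gives a 1.3-fold higher number from compound 1 to compound 3 (0.13 log units; within the scatter), so compound 1 and compound 3 cannot be told apart. Nothing available explains the gap between the two rings.

Open, on these data alone, is whether phenyl or thiophen-3-yl would stay with compound 3 or with compound 2. An amine on the thiophen-2-yl ring is also untested among the compounds shown here.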